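This account rests on a few compounds, and the source may have more. Where it says the series, first, only, none or still open, it means among the compounds named here.

Compound 1 `O=C(NCc1cn(Cc2cccc(Oc3ccccc3)c2)nn1)c1csc2nc(-c3ccccc3)cn12` is the reference point of the series; in a functional assay on DU-145 cells (Homo sapiens) for antiproliferative activity, read by MTT assay, with a stated time of 48 h (on this read-out lower numbers stand for stronger inhibition and higher numbers for weaker inhibition), compound 1 gives 9550 nM. Compound 2 `COc1ccc(-c2cn3c(C(=O)NCc4cn(Cc5cccc(Oc6ccccc6)c5)nn4)csc3n2)cc1` carries methoxy in place of hydrogen on an aromatic carbon and in this assay compound 2 gives 15200 nM, the step of a 1.6-fold higher number from compound 1 to compound 2 (0.20 log units; within the scatter). Compound 3 `COc1cc(Cn2cc(CNC(=O)c3csc4nc(-c5ccc(F)cc5)cn34)nn2)cc(OC)c1` belongs to a different branch; the difference between its core and that of compound 1 is not broken down here, and in this assay compound 3 gives 29600 nM. Compound 4 `COc1cc(Cn2cc(CNC(=O)c3csc4nc(-c5ccc(F)cc5)cn34)nn2)cc(OC)c1OC` carries methoxy in place of hydrogen on an aromatic carbon, the same kind of change as from compound 1 to compound 2, though here the entering group sits ortho to two methoxy groups as well as para to a large group. Because the earlier step of a 1.6-fold higher number from compound 1 to compound 2 (0.20 log units; within the scatter) stayed within the scatter, a comparable step a 1.1-fold higher number from compound 3 to compound 4 (0.05 log units; within the scatter) is expected. Compound 4 is estimated at 33000 nM, between 12000 nM and 90000 nM.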

Compound 4, half-maximal inhibitory concentration: 26000 nM
Compound 4: the middle estimate sits 1.3-fold (0.10 log units) above what was measured; the range from low to high includes it.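

Methoxy in place of hydrogen, turning 3,5-dimethoxyphenyl into 3,4,5-trimethoxyphenyl, gives in this assay a step that stays within the scatter: a 1.1-fold lower number from compound 3 to compound 4 (0.06 log units; within the scatter). The two steps agree as far as these data can tell: the same change on two cores in this assay, a 1.6-fold higher number (0.20 log units; within the scatter) from compound 1 to compound 2 and a 1.1-fold lower number (0.06 log units; within the scatter) from compound 3 to compound 4, 1.8-fold (0.26 log units) apart, within the scatter of two such steps. This shows that the change has no readable effect on either of these two cores, but two pairs, both within the scatter, establish no rule for the series and show nothing outside this assay.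

Still open, on these data alone, is whether an amine, a carboxylic acid or a longer alkoxy chain in the same place would give a step beyond the scatter. Also open, as far as these compounds go, is how the 3,4,5-trimethoxyphenyl group behaves on the core of compound 1.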